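The source may hold more compounds than are shown below. What is called first, only, known or untested is meant among the compounds shown, and "the series" means these compounds.

Notes on the series. Within the data shown here, compound 1 `COC(=O)c1ccc(NCc2cncn2Cc2cccc(Br)c2)cc1-c1ccccc1` is one of two compounds measured in a toxicity assay on NIH3T3 cells (Mus musculus) for cytotoxicity, read by resazurin assay; a higher number here means that more compound is needed for the effect, a lower number that less compound is needed. In this assay compound 1 gives > 10000 nM, which is a limit of the assay and not a number (the limit of > 10000 nM in this assay, at which 1 of the 2 values shown sits). Compound 2 `c1ccc(Cn2cncc2CNc2cccc(-c3ccncc3)c2)cc1` is the other measured member; in this assay compound 2 gives > 1000 nM, again a limit of the assay rather than a number (the limit of > 1000 nM in this assay, at which 1 of the 2 values shown sits). Among the measured compounds shown here, no step between measured compounds can be formed, so compound 1 stands only as a limit, with one further limit beside it. Compound 3 `COC(=O)c1ccc(NCc2cncn2Cc2ccccc2C#N)cc1-c1ccccc1` is not yet measured. The change from compound 1 to compound 3 is 2-cyanophenyl in place of 3-bromophenyl on a saturated chain carbon bound to an aromatic nitrogen. For the measured compounds named here, with no measured step to lean on, the step expected in this assay is a step that the limit leaves unreadable from compound 1 to compound 3, nothing beyond the usual scatter. Compound 3 is therefore expected to give about 15000 nM in this assay, in the range 5000 nM to 50000 nM, most likely reported again only as a limit.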

Compound 3, half-maximal effective concentration: 25000 nM
For compound 3 the middle estimate is 1.7-fold (0.22 log units) below the measured one; the measured number falls inside the stated range.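

No step can be read from compound 1 to compound 3, since compound 1 stands in this assay only as a limit of the assay and not as a number: the limit of > 10000 nM in this assay, at which 1 of the 3 values shown sits.

The compounds shown leave open how large a step 2-cyanophenyl in place of 3-bromophenyl gives in this assay.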